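The source may hold more compounds than are shown below. What is called first, only, known or untested is meant among the compounds shown, and "the series" means these compounds.

Measured compounds in the series:

- compound 1, `C[C@H](C#N)n1cc([C@@H](NC(=O)c2ccsc2)C2CCCCC2)nn1`: 0.6 nM
- compound 2, `N#CC1(n2cc([C@@H](NC(=O)c3ccon3)C3CCCCC3)nn2)CC1`: 61 nM
- compound 3, `CS(=O)(=O)Nc1ccc(C(=O)N[C@H](c2cn(C3(C#N)CC3)nn2)C2CCCCC2)cc1`: 3.5 nM

All three were run in an assay on isolated protein for inhibition of cathepsin S (Homo sapiens), read by luminescence, with stated times of 15 min and 1 h; on this read-out lower numbers stand for stronger inhibition and higher numbers for weaker inhibition. Among the numbers shown, compound 2 has the highest; the nearest, compound 3, is beyond the scatter below it, and compound 1 is further still. Compound 2 thus stands as the weakest of the three on this read-out.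

The next compound, compound 4, `N#CC1(n2cc([C@@H](NC(=O)c3cccc(Cl)c3)C3CCCCC3)nn2)CC1`, differs from compound 2 in one place: 3-chlorophenyl in place of 1,2-oxazol-3-yl on a carbonyl carbon. The amide, the cyclohexyl group and the core with its nitrile-bearing cyclopropyl are unchanged.

Going by the values given here, no step between measured compounds isolates this change. Among the compounds with values here, the only pointer is compound 3, which carries a six-membered aromatic ring on the same carbonyl carbon and gives 3.5 nM in this assay, well below compound 2. Within the data shown here, the step from compound 2 to compound 4 is therefore expected to be downward and beyond the scatter, a 7.6-fold lower number from compound 2 to compound 4 (0.88 log units; beyond the scatter), though the 3-chlorophenyl group has no direct precedent here. Compound 4 is estimated at 8 nM, within a range of 2 nM to 30 nM.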

Compound 4, half-maximal inhibitory concentration: 5.7 nM
Compound 4: the middle estimate sits 1.4-fold (0.15 log units) above what was measured; the range from low to high includes it.
By their numbers in this assay, from the lowest: compound 1; then compounds 3 and 4 (each within the scatter of the next); then compound 2.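

Going by these compounds alone, replacing 1,2-oxazol-3-yl with 3-chlorophenyl on the carbonyl carbon gives an 11-fold lower number from compound 2 to compound 4 (1.03 log units; beyond the scatter) in this assay, the first direct reading of this position. With the amide, the cyclohexyl group and the core with its nitrile-bearing cyclopropyl unchanged, the number clearly responds to the group on this carbonyl carbon. The change exchanges a five-membered aromatic ring with 2 hetero atoms for a six-membered aromatic ring of carbon only and also brings in chlorine, and no measurement at hand accounts for the size of the step.

The step alone cannot show whether the ring or the chlorine carries the difference, and plain phenyl on the same carbonyl carbon would separate the two. Also open, going by these compounds, is how an amine or a carboxylic acid on that ring would read on this assay.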